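Replacing a difluorophenyl with fluorophenyl: tolerated concentration

The compounds below may be only part of what the source reports. "The series", "measured", "known", "first", "only" and "open" are said of these compounds alone.

Measured so far:
compound 1 `COc1ccn2c(Nc3cc(F)cc(F)c3)c(-c3ccccn3)nc2c1`: 4300 nM
compound 2 `c1ccn2c(NC3CCCC3)c(-c3nccs3)nc2c1`: > 50000 nM
compound 3 `Fc1ccc(Nc2c(-c3ccc(Cl)cn3)nc3ccccn23)cc1`: > 50000 nM

Going by the values given here, in an ADME assay on THP-1 cells (Homo sapiens) for cytotoxicity (a higher number here means that more compound is tolerated, a lower number that less compound is tolerated), compound 1 gives 4300 nM, the only actual number among the three. For compound 2 the result is a limit of the assay, > 50000 nM. For compound 3 the result is likewise a limit of the assay, > 50000 nM. Compound 1 therefore stands as the single measured point, with the limit of > 50000 nM in this assay, at which 2 of the 3 values shown sit, covering the other two. Compound 4 `COc1ccn2c(Nc3ccc(F)cc3)c(-c3ccccn3)nc2c1` differs from compound 1 in one place: 4-fluorophenyl in place of 3,5-difluorophenyl on a nitrogen on an aromatic ring. Among the compounds with values here, no measured pair shows this change, so its size is open; a modest rise in tolerated concentration, somewhat beyond the scatter, is expected rather than a fall. A step of a 2.3-fold higher number from compound 1 to compound 4 (0.37 log units; beyond the scatter) is expected. Compound 4 is expected to give about 10000 nM, within 3000 nM to 50000 nM.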

Compound 4, half-maximal cytotoxic concentration: 4560 nM
The estimate for compound 4 lay 2.2-fold (0.34 log units) above the measured number; the measured number falls inside the stated range.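

Going by these compounds alone, exchanging 3,5-difluorophenyl for 4-fluorophenyl on the nitrogen gives, in this assay, a 1.1-fold higher number from compound 1 to compound 4 (0.03 log units; within the scatter) as the first one-place comparison in this set. At this position, then, going from two fluorines to one, in a different arrangement on the ring, leaves the tolerated concentration unchanged within normal assay variation. Nothing available here explains this result.

Still open, from the compounds shown here alone, is whether an unsubstituted phenyl or a phenyl carrying an amine or a carboxylic acid would behave the same way. Compound 2 and compound 3 differ from compound 4 in more than one place, so what separates them from it cannot be read.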